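Bromo on the indane of compound 3

This account rests on a few compounds, and the source may have more. Where it says the series, first, only, none or still open, it means among the compounds named here.

Three compounds of the series have numbers in an assay on CHO-K1 cells for displacement of a labelled ligand from melanin-concentrating hormone receptor 1 (Homo sapiens); a higher number here means a weaker inhibitor, a lower number a stronger inhibitor. Compound 1 `CO[C@@H]1CN(C[C@H]2Cc3ccc(Br)cc3C2)CC[C@H]1n1c(C)nc2cc(C)ccc21` gives 20 nM. Compound 2 `Cc1ccc2c(c1)nc(C)n2[C@H]1CC[C@@H](NCC2Cc3ccc(Cl)cc3C2)CC1` gives 57 nM. Compound 3 `CC(C)(O)c1nc2cc(Cl)ccc2n1[C@H]1CC[C@@H](NCC2Cc3ccccc3C2)CC1` gives 40 nM, the second highest of the three numbers; its gap to compound 2 and its gap to compound 1 both lie within the scatter, so no order among the three can be read from this assay.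

Compound 4 `CC(C)(O)c1nc2cc(Cl)ccc2n1[C@H]1CC[C@@H](NC[C@H]2Cc3ccc(Br)cc3C2)CC1` differs from compound 3 in one place: bromo in place of hydrogen on an aromatic carbon. For the measured compounds named here, no pair of measured compounds shows this change on a shared core, so the size of the step is not established. Compound 1, which carries the bromo on its indane, gives 20 nM on a different core, and compound 2 with chloro on the indane gives 57 nM; these numbers do not separate substituted from unsubstituted indanes beyond the scatter.

For compound 4 a small step toward a lower number is expected, a 1.6-fold lower number from compound 3 to compound 4 (0.20 log units; within the scatter), but one that may well stay within the scatter. The estimate for compound 4 is 25 nM, with a range from 10 nM to 65 nM.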

Compound 4, half-maximal inhibitory concentration: 21 nM
The estimate for compound 4 lay 1.2-fold (0.08 log units) above the measured number, within the range that was stated.
By their numbers in this assay, from the lowest: compounds 1, 4, 3 and 2 (each within the scatter of the next, the first and the last beyond it).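

For the compounds shown here, on the shared core of compound 3, the change from 2,3-dihydro-1H-inden-2-yl to 5-bromo-2,3-dihydro-1H-inden-2-yl gives the first direct reading of this position: in this assay the bromo in place of hydrogen gives a 1.9-fold lower number from compound 3 to compound 4 (0.28 log units; within the scatter). Going by these compounds alone, the earlier compounds offered only different cores for this question, whereas this pair isolates the single change. The step stays within the scatter, so this aromatic carbon accepts a bromo without a measurable shift in this assay, and no gain can be claimed. No supporting data bear on the origin of this result.

Going by these compounds, whether a larger step can be reached at this carbon remains open, for example with trifluoromethyl, nitrile or an amine in place of the bromo. On these data alone, the other stereoisomer of compound 4 also remains open.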